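Nitro to amino on the ketone-side ring of two chalcones

The source may hold more compounds than are shown below. What is called first, only, known or untested is meant among the compounds shown, and "the series" means these compounds.

Measured so far: compound 1 `COc1cc(/C=C/C(=O)c2ccc(OC)c(N)c2)cc(OC)c1`, 8800 nM in a functional assay on B16 cells (Mus musculus) for cytotoxicity, read by MTT assay, with a stated time of 3 days; a higher number here means a weaker inhibitor, a lower number a stronger inhibitor; compound 2 `COc1ccc(C(=O)/C=C/c2cc(OC)c(OC)c(OC)c2)cc1[N+](=O)[O-]`, > 100000 nM.

Compound 2 sits only at a limit of this assay, (the limit of > 100000 nM in this assay, at which 1 of the 2 values shown sits), so no number is known for it. Compound 3 `COc1ccc(C(=O)/C=C/c2cc(OC)c(OC)c(OC)c2)cc1N` carries the change (amino in place of nitro on an aromatic carbon), amino in place of nitro on an aromatic carbon. Going by the values given here, no step between measured compounds covers this change. Compound 1, which also carries an amino group, gives 8800 nM. A gain in potency is expected for compound 3, with a step from an at least 33-fold lower number from compound 2 to compound 3 (1.52 log units; beyond the scatter) well beyond the scatter. Compound 3 is estimated at 3000 nM, within 300 nM to 30000 nM.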

Compound 3, half-maximal inhibitory concentration: 67000 nM
Compound 3: middle estimate off by 22-fold (1.35 log units), on the low side, and the stated range ends below it.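

In this assay compound 2 stands only at a limit and not at a number: the limit of > 100000 nM in this assay, at which 1 of the 3 values shown sits. Amino in place of nitro on an aromatic carbon therefore yields only a floor in an at least 1.4-fold lower number from compound 2 to compound 3 (0.17 log units; that floor lies within the scatter) and its true size stays unknown. Methoxy in place of hydrogen on an aromatic carbon gives the only firm step among these amino compounds with a 7.6-fold higher number from compound 1 to compound 3 (0.88 log units; beyond the scatter) as its size. Going by these compounds, how a dimethylamino or acetamido group would compare with amino on this carbon stays open, as does a hydroxyl group there.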